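The source may hold more compounds than are shown below. What is called first, only, known or untested is meant among the compounds shown, and "the series" means these compounds.

Compound 1 `C=C1C(=O)OC[C@@H]1CCOC(=O)Nc1ccc(C(C)C)cc1`: 1580 nM in a functional assay on RAW264.7 cells (Mus musculus) for inhibition, with a stated time of 30 min; on this read-out lower numbers stand for stronger inhibition and higher numbers for weaker inhibition
Compound 2 `C=C1C(=O)OC[C@@H]1CCOC(=O)Nc1ccc(I)cc1`: 790 nM
Compound 3 `C=C1C(=O)OC[C@@H]1CCOC(=O)Nc1ccc(CCCC)cc1`: 1230 nM

The three compounds share one core and differ only in the group carried on an aromatic carbon. Compound 3 stands second highest of the three numbers shown, yet every step between them lies within the usual scatter of the measurement: a 2.0-fold lower number from compound 1 to compound 2 (0.30 log units; within the scatter), a 1.3-fold lower number from compound 1 to compound 3 (0.11 log units; within the scatter) and a 1.6-fold higher number from compound 2 to compound 3 (0.19 log units; within the scatter). Exchanging one group for another on that carbon has thus left the read-out essentially unchanged.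

Compound 4 `C=C1C(=O)OC[C@@H]1CCOC(=O)Nc1ccccc1` differs from compound 3 by hydrogen in place of butyl on an aromatic carbon. Within the data shown here, the steps that bear on it are the two that also alter this group, a 1.3-fold lower number from compound 1 to compound 3 (0.11 log units; within the scatter) and a 1.6-fold higher number from compound 2 to compound 3 (0.19 log units; within the scatter), both small. Among the measured compounds shown here, none of the measured steps removes the group altogether, so the step to compound 4 has no direct precedent, but nothing seen so far points to a change beyond the scatter in this assay.

Compound 4 is therefore expected to give 2000 nM in this assay, with an estimated range from 800 nM to 5000 nM. This estimate corresponds to an expected step of a 1.6-fold higher number from compound 3 to compound 4 (0.21 log units; within the scatter).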

Compound 4, half-maximal inhibitory concentration: 780 nM
The estimate for compound 4 lay 2.6-fold (0.41 log units) above the measured number, and the stated range ends above it.
By their numbers in this assay, from the lowest: compounds 4, 2, 3 and 1 (each within the scatter of the next, the first and the last beyond it).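

Removing the group altogether costs nothing measurable in this assay: hydrogen in place of butyl gives a small step (a 1.6-fold lower number from compound 3 to compound 4 (0.20 log units; within the scatter)), and hydrogen in place of iodo gives almost none (a 1.0-fold lower number from compound 2 to compound 4 (0.01 log units; within the scatter)). The unsubstituted ring therefore holds up as well as the butyl and iodo compounds, so this aromatic carbon needs no added group for the inhibition seen here. Only hydrogen in place of isopropyl passes beyond the scatter (a 2.0-fold lower number from compound 1 to compound 4 (0.31 log units; beyond the scatter)), and that step is modest. No measurement here explains these results.

Going by these compounds, whether a group such as an amine or a carboxylic acid on this carbon would move the number further remains open. So does whether a chain longer than butyl would stay within the scatter.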